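A few compounds are considered here, and "the series" means these few. Any claim that something is new, unique, unknown or untested is made for them only; others in the source may bear on it.

Measured so far:
- Compound 1 `CC(C)(C)c1nc(-c2ccsc2)c2c(N)c(C#N)c(N)nc2n1`: 40000 nM
- Compound 2 `CC(C)(C)c1nc(-c2cnccn2)c2c(N)c(C#N)c(N)nc2n1`: 86000 nM

In a physicochemical assay for solubility, in phosphate buffer, with a stated time of 18 h (on this read-out lower numbers stand for lower solubility and higher numbers for higher solubility), compound 2 gives 86000 nM, the higher of the two numbers available, and it stands clearly clear of compound 1 at 40000 nM.

The next compound, compound 3 `CC(C)(C)c1nc(-c2ccn[nH]2)c2c(N)c(C#N)c(N)nc2n1`, keeps the shared core and alters one group: 1H-pyrazol-5-yl in place of pyrazin-2-yl on an aromatic carbon. In words, 1H-pyrazol-5-yl takes the place of pyrazin-2-yl on an aromatic carbon.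

For the measured compounds named here, only one measured step bears on this change: a 2.2-fold higher number from compound 1 to compound 2 (0.33 log units; beyond the scatter). There, too, one aromatic ring replaced another on an aromatic carbon, and the number moved modestly, though beyond the scatter. Going by the values given here, this is a single pair, and no measured compound carries 1H-pyrazol-5-yl, so the evidence is thin and the direction is uncertain. With compound 2 the highest so far, a small drop seems slightly more likely than a further rise. The expected change in this assay is therefore small: a 1.3-fold lower number from compound 2 to compound 3 (0.12 log units; within the scatter). Compound 3 is estimated at 65000 nM, with an expected range of 25000 nM to 170000 nM.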

Compound 3, solubility: 13500 nM
Beside the measured number, compound 3's estimate is 4.8-fold (0.68 log units) above it; the measured number lies below the stated range.
By their numbers in this assay, from the lowest: compound 3; then compound 1; then compound 2.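

In this assay, for the compounds shown here, this position on the shared core proves able to move the number further down than the earlier compounds showed: 1H-pyrazol-5-yl in place of pyrazin-2-yl gives a 6.4-fold lower number from compound 2 to compound 3 (0.80 log units; beyond the scatter), and 1H-pyrazol-5-yl in place of thiophen-3-yl gives a 3.0-fold lower number from compound 1 to compound 3 (0.47 log units; beyond the scatter), which leaves compound 3 lowest of the three. Pyrazin-2-yl and 1H-pyrazol-5-yl each hold a ring with 2 hetero atoms, so an equal count of hetero atoms does not go with similar numbers here, while the entering ring is five-membered and has 1 hydrogen-bond donor where the leaving ring is six-membered and has 0. No measurement at hand explains why the number fell with this change.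

The compounds shown leave open whether the drop follows the hydrogen-bond donor or some other feature of 1H-pyrazol-5-yl, a question that a methyl group on its ring nitrogen would help to separate. They also leave open where a plain phenyl ring or a pyridine ring at this position would fall among these three numbers.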